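Replacing the Side-Chain Acid of a Cyclic Dipeptide

The source may report more compounds than this note shows. Statements on the series, on what has been measured and on what is new or still open speak of the compounds shown alone.

For the measured compounds named here, compound 1 `CC(C)C[C@@H]1NC(=O)[C@H](CCC(=O)O)NC1=O` gives 97.8% in a functional assay, tested at 2.5 mM (on this read-out lower numbers stand for less inhibition and higher numbers for more inhibition at the one concentration tested (going by the name of the read-out)), the highest of the two numbers measured so far. Its nearest neighbour, compound 2 `CC(C)C[C@@H]1NC(=O)[C@H](CCC(N)=O)NC1=O`, gives 19% in this assay. Going by the values given here, the only measured step, a number 78.8 percentage points lower from compound 1 to compound 2 (beyond the scatter), is amino in place of hydroxy on a carbonyl carbon, and it is large and beyond the scatter. Compound 3 `CSCC[C@@H]1NC(=O)[C@H](CC(C)C)NC1=O` differs from compound 1 by methylsulfanyl in place of carboxy on a saturated chain carbon, two bonds along the chain from a saturated ring carbon. Among the compounds with values here, no measured step covers this exchange directly, but the step from compound 1 to compound 2 is the one that bears on it: there the carboxy was also altered, and the read-out fell steeply. With the carboxy now leaving altogether in favour of methylsulfanyl, a comparable loss seems likely. For compound 3 a large downward step is therefore expected, a number 72.8 percentage points lower from compound 1 to compound 3 (beyond the scatter). Compound 3 is estimated at 25%, with a range from 5% to 55%.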

Compound 3, a percentage reported as inhibition, at one concentration (the size of the read-out at that concentration, not a potency): 79%
Compound 3: the middle estimate sits 54 percentage points below what was measured; the whole stated range lies below it.
By their numbers in this assay, from the lowest: compound 2; then compound 3; then compound 1.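

In this assay the carboxy proves not to be required for a high number at this position: methylsulfanyl in its place gives a number 18.8 percentage points lower from compound 1 to compound 3 (beyond the scatter) and this step is only modest. The same methylsulfanyl set against the carbamoyl gives a number 60 percentage points higher from compound 2 to compound 3 (beyond the scatter) and this large step makes the low number of compound 2 a matter of the carbamoyl specifically, not simply of losing the carboxy. Nothing available explains this order among the three groups.

Going by these compounds, it remains open whether an amine at the end of this chain would read high like compound 1 and compound 3 or low like compound 2. Also open, on these data alone, is whether a longer chain carrying the carboxy or the methylsulfanyl would keep the high number.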